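This account rests on a few compounds, and the source may have more. Where it says the series, first, only, none or still open, it means among the compounds named here.

Of the compounds shown here, three that share much of their build have been tested in a functional assay on the whole organism (artery, strain albino) with Rattus norvegicus as the target, with a stated time of 360 min, at a dose of 10 mg/kg by the oral route; a higher number here means more inhibition at the dose given (going by the name of the read-out), a lower number less inhibition. Compound 1 `COc1ccc(C2N=C(SCc3cccc(Cl)c3)NC(C)=C2C(=O)Nc2ccc(F)cc2)cc1OC` gives 20.1% there. Compound 2 `COc1ccc(C2N=C(SCc3ccc(Cl)cc3)NC(C)=C2C(=O)Nc2ccc(F)cc2)cc1OC` gives 37.1% in this assay. These two differ in a single spot: 4-chlorophenyl in place of 3-chlorophenyl on a saturated chain carbon bound to a sulfur. For the measured compounds named here, that change produced a number 17 percentage points higher from compound 1 to compound 2 (beyond the scatter), and it is the one step in this set that can be read directly from two measured numbers.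

Compound 3 `CC1=C(C(=O)Nc2ccc(Br)cc2)C(c2ccc(Cl)cc2Cl)N=C(SCc2cccc(Cl)c2)N1` rests on a different core; how its core differs from that of compound 1 is not broken down here. In this assay, going by the values given here, compound 3 gives 20.6%, a number that sits within the usual scatter of the one for compound 1 and clearly under the one for compound 2.

Compound 4 `CC1=C(C(=O)Nc2ccc(Br)cc2)C(c2ccc(Cl)cc2Cl)N=C(SCc2ccc(Cl)cc2)N1` has not yet been measured. It stands to compound 3 as compound 2 stands to compound 1: 4-chlorophenyl in place of 3-chlorophenyl on a saturated chain carbon bound to a sulfur. The change is the same one at the same place, only carried onto the other core. Among the compounds with values here, whether it will behave the same way on a new core cannot be known from one example, and the earlier pair is the only guide, so any expectation must be held loosely.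

Compound 4 is expected to show a number 15.4 percentage points higher from compound 3 to compound 4 (beyond the scatter), a step of about the size of the earlier one, because the same change gave a number 17 percentage points higher from compound 1 to compound 2 (beyond the scatter). On that basis compound 4 is estimated at 36%, with a likely range from 20% to 52%.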

Compound 4, a percentage reported as inhibition, in the whole organism at one dose (the size of the read-out at that dose, not a potency): 39.7%
Compound 4: the middle estimate sits 3.7 percentage points below what was measured; the range from low to high includes it.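

Within this assay the swap of 3-chlorophenyl for 4-chlorophenyl on the second core gave a number 19.1 percentage points higher from compound 3 to compound 4 (beyond the scatter) and so repeated what it had done on the first core. Set side by side, the two steps agree in direction and in size: the same change on two cores in this assay, a number 17 percentage points higher (beyond the scatter) from compound 1 to compound 2 and a number 19.1 percentage points higher (beyond the scatter) from compound 3 to compound 4, 2.1 percentage points apart, within the scatter of two such steps. This shows that the change carried over between these two cores, in this one whole-animal test at a single dose, but two cores make no general rule, and nothing here explains why the 4-chlorophenyl compounds give the higher numbers or predicts what the change would do on a third core.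

The compounds shown hold only the 3-chlorobenzyl and 4-chlorobenzyl groups on the sulfur, so they leave open how a plain benzyl, a 4-methoxybenzyl or a longer chain would fare in that place. They also leave open whether any of the other differences between the two cores could alter the size of this step, and whether the same step would appear at other doses or other times.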